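A few compounds are considered here, and "the series" means these few. Any claim that something is new, unique, unknown or untested is made for them only; others in the source may bear on it.

Of the compounds shown here, two have been measured so far in an in vitro ADME assay on microsomes from liver (Mus musculus) for pharmacokinetics, read by LC-MS, with a stated time of 10 min, tested at 1 uM; on this read-out lower numbers stand for slow clearance and higher numbers for fast clearance. Compound 1 (`CN1C[C@H](C(=O)Nc2ccccc2)[C@@H](c2ccc(/C=C/C(=O)Nc3ccccc3N)cc2)C1`) gives 67 mL/min/kg and compound 2 (`Cc1ccc(NC(=O)[C@H]2CN(C)C[C@@H]2c2ccc(/C=C/C(=O)Nc3ccccc3N)cc2)cn1`) gives 57 mL/min/kg. Among the compounds with values here, the one measured step runs a 1.2-fold lower number from compound 1 to compound 2 (0.07 log units; within the scatter), so compound 2 cannot be separated from compound 1 on these numbers.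

Compound 3 (`CN1C[C@H](C(=O)N2CCCCC2)[C@@H](c2ccc(/C=C/C(=O)Nc3ccccc3N)cc2)C1`) keeps the shared core and alters the group on the carbonyl carbon: piperidin-1-yl in place of (6-methylpyridin-3-yl)amino on a carbonyl carbon. Piperidin-1-yl thus stands in place of (6-methylpyridin-3-yl)amino, which turns (6-methylpyridin-3-yl)carbamoyl into (piperidin-1-yl)carbonyl.

The measured step bears on this change only in part. Within the data shown here, it exchanged phenyl for 6-methylpyridin-3-yl on an amide-type nitrogen, and neither measured compound carries piperidin-1-yl, so the data offer no direct precedent. Among the measured compounds shown here, the only guide is that compound 2 and compound 1 sit together, with a 1.2-fold lower number from compound 1 to compound 2 (0.07 log units; within the scatter) as their whole separation. No shift beyond the scatter is therefore expected in this assay, and no direction can be favoured, with the expected step reading a 1.1-fold higher number from compound 2 to compound 3 (0.02 log units; within the scatter). For compound 3 the estimated clearance is 60 mL/min/kg, with an expected range from 32 mL/min/kg to 105 mL/min/kg.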

Compound 3, clearance: 42 mL/min/kg
Beside the measured number, compound 3's estimate is 1.4-fold (0.15 log units) above it; measured number inside the range.
By their numbers in this assay, from the lowest: compounds 3, 2 and 1 (each within the scatter of the next).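

In this assay the earlier pair only exchanged one aromatic ring for another on an amide-type nitrogen, whereas compound 3 replaces the whole amino group on the carbonyl carbon with piperidin-1-yl, a non-aromatic ring with 0 hydrogen-bond donors. Even this wider exchange gives a 1.4-fold lower number from compound 2 to compound 3 (0.13 log units; within the scatter) and, against the phenyl-bearing compound, a 1.6-fold lower number from compound 1 to compound 3 (0.20 log units; within the scatter), so at this place neither the aromatic ring nor the hydrogen-bond donor of the leaving group is shown to matter for clearance on these numbers. Nothing available explains why these three compounds sit so close together.

What remains open is whether any group on this carbonyl carbon can move clearance beyond the scatter, since the three compounds shown span only anilino, (6-methylpyridin-3-yl)amino and piperidin-1-yl. A morpholin-4-yl ring, an open-chain dimethylamino group or a piperazin-1-yl ring at the same place would test that, and the compounds shown say nothing about how any of these would read.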